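The source may report more compounds than this note shows. Statements on the series, on what has been measured and on what is new or still open speak of the compounds shown alone.

Measured so far in an assay on isolated protein for inhibition of proto-oncogene tyrosine-protein kinase receptor Ret variant V804M (Homo sapiens), read by 33P incorporation, with stated times of 15 min and 40 min; on this read-out higher numbers stand for weaker inhibition and lower numbers for stronger inhibition:
- compound 1, `COc1ccc(NC(=O)Nc2ccc(Nc3ncnc4c3OCCN4)cc2)cc1`, gives 824 nM
- compound 2, `CC(C)(C)c1cc(NC(=O)Nc2ccc(Nc3ncnc4c3OCCN4)cc2)no1`, gives 34 nM

Going by the values given here, compound 2 holds the lower of the two numbers in this assay; the only measured step, a 24-fold lower number from compound 1 to compound 2 (1.38 log units; beyond the scatter), shows that the group on this amide-type nitrogen matters greatly. Compound 3, `O=C(Nc1ccc(Nc2ncnc3c2OCCN3)cc1)Nc1cccs1`, carries thiophen-2-yl in place of 5-(tert-butyl)-1,2-oxazol-3-yl on an amide-type nitrogen. Among the compounds with values here, no measured step covers a thiophen-2-yl here, so the expectation rests on compound 2 and on the size of the step from compound 1 alone. With the tert-butyl-bearing ring gone, compound 3 is expected to give a higher number, estimated as an 8.8-fold higher number from compound 2 to compound 3 (0.95 log units; beyond the scatter), a value of 300 nM in a range of 80 nM to 1200 nM.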

Compound 3, half-maximal inhibitory concentration: 8640 nM
The estimate for compound 3 lay 29-fold (1.46 log units) below the measured number; measured number outside the range, above it.
By their numbers in this assay, from the lowest: compound 2; then compound 1; then compound 3.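

In this assay, thiophen-2-yl in place of 5-(tert-butyl)-1,2-oxazol-3-yl gives a 250-fold higher number from compound 2 to compound 3 (2.41 log units; beyond the scatter), and in place of 4-methoxyphenyl it gives a 10-fold higher number from compound 1 to compound 3 (1.02 log units; beyond the scatter). A five-membered aromatic ring on this amide-type nitrogen is therefore not enough to reach the low number of compound 2, and here it falls behind the 4-methoxyphenyl of compound 1. Nothing available explains this result.

The compounds shown leave open whether the tert-butyl group or the 1,2-oxazole ring matters more. A thiophen-2-yl carrying tert-butyl, or a 1,2-oxazol-3-yl without it, would separate the two.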